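The source may report more compounds than this note shows. Statements on the series, on what has been measured and on what is new or still open speak of the compounds shown alone.

In a functional assay on PC-3 cells (Homo sapiens) for inhibition, read by MTT assay, with a stated time of 72 h (a lower number here means a stronger inhibitor, a higher number a weaker inhibitor), three compounds built on a shared core have been measured so far. Compound 3 `O=C(/C=C/c1cc([N+](=O)[O-])ccc1Cl)/C=C/c1ccccc1Oc1ncnc2ccc(Cl)cc12` gives 2510 nM, the lowest number of the three. Compound 1 `O=C(/C=C/c1ccc(Cl)c([N+](=O)[O-])c1)/C=C/c1ccccc1Oc1ncnc2ccc(Cl)cc12` gives 9760 nM, and compound 2 `O=C(/C=C/c1ccc(Oc2ncnc3ccc(Cl)cc23)cc1)/C=C/c1ccc(Cl)c([N+](=O)[O-])c1` gives 11800 nM, a higher number than compound 3 shows. Among the compounds with values here, the only single-change step measured, a 3.9-fold lower number from compound 1 to compound 3 (0.59 log units; beyond the scatter), came from a different arrangement of chlorine and nitro on the same aryl ring.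

Compound 4 `O=C(/C=C/c1ccc(Cl)c(Cl)c1)/C=C/c1ccccc1Oc1ncnc2ccc(Cl)cc12` differs from compound 3 in one place: 3,4-dichlorophenyl in place of 2-chloro-5-nitrophenyl on a double-bonded chain carbon bound to a double-bonded chain carbon. Within the data shown here, no measured pair exchanges a nitro group for a chlorine, so that one step is the only guide, and it concerns a rearrangement of the same two groups rather than an exchange of one for another. It shows that a change on this ring can move the result beyond the scatter, but it does not tell which direction the present exchange would take. A modest shift of uncertain direction is therefore expected, with a wide range. Compound 4 is expected to give 4000 nM (range 1300 nM to 12000 nM), which would mean an estimated step of a 1.6-fold higher number from compound 3 to compound 4 (0.20 log units; within the scatter).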

Compound 4, half-maximal inhibitory concentration: 18300 nM
The estimate for compound 4 lay 4.6-fold (0.66 log units) below the measured number; the whole stated range lies below it.
By their numbers in this assay, from the lowest: compound 3; then compounds 1, 2 and 4 (each within the scatter of the next).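

In this assay, within the data shown here, 3,4-dichlorophenyl in place of 2-chloro-5-nitrophenyl gives a 7.3-fold higher number from compound 3 to compound 4 (0.86 log units; beyond the scatter), which supplies the direction that the earlier compounds could not: this exchange, on a double-bonded chain carbon bound to a double-bonded chain carbon, does not preserve the lowest number in the set. Chloro in place of nitro on an aromatic carbon gives a 1.9-fold higher number from compound 1 to compound 4 (0.27 log units; within the scatter), so the nitro group alone does not set the result, and the low number of compound 3 goes with its full 2-chloro-5-nitrophenyl pattern. Nothing available explains either step.

The compounds shown leave open whether both the chlorine and the nitro group of that pattern are needed. They also leave open whether an amine or a carboxylic acid in the place of that nitro group would keep the lower number.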